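Aryl group change from compound 3 to compound 4

The source may report more compounds than this note shows. Statements on the series, on what has been measured and on what is new or still open speak of the compounds shown alone.

Values in a functional assay on HepG2 cells (Homo sapiens) for inhibition, read by MTT assay, with a stated time of 48 h; a lower number here means a stronger inhibitor of growth, a higher number a weaker inhibitor of growth:
- compound 1 `COc1ccc2c(c1)c(C1CC(c3ccc(F)cc3)=NN1C(=O)c1ccc(OC)nc1)cn2C`: 220 nM
- compound 2 `COc1ccc2c(c1)c(C1CC(c3ccc(Br)cc3)=NN1C(=O)c1ccc(OC)nc1)cn2C`: > 10000 nM, a limit of the assay and not a number
- compound 3 `COc1ccc(C2=NN(C(=O)c3ccc(OC)nc3)C(c3cn(C)c4ccc(OC)cc34)C2)cc1`: 230 nM

Compound 3 stands level with compound 1, as a 1.0-fold higher number from compound 1 to compound 3 (0.02 log units; within the scatter) shows. Both lie well clear of the limit reached by compound 2, as an at least 43-fold lower number from compound 2 to compound 3 (1.63 log units; beyond the scatter) shows.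

Compound 4 `COc1ccc2c(c1)c(C1CC(c3cc(OC)c(OC)c(OC)c3)=NN1C(=O)c1ccc(OC)nc1)cn2C` carries 3,4,5-trimethoxyphenyl in place of the 4-methoxyphenyl of compound 3, on a carbon with a double bond to nitrogen: 3,4,5-trimethoxyphenyl in place of 4-methoxyphenyl on a carbon with a double bond to nitrogen.

The measured steps all exchange one group on an aromatic carbon of this aryl group, but none of them adds methoxy groups as this change does. They also differ widely in size. The exchange of fluoro for methoxy gives a 1.0-fold higher number from compound 1 to compound 3 (0.02 log units; within the scatter), while the exchange of fluoro for bromo gives an at least 45-fold higher number from compound 1 to compound 2 (1.65 log units; beyond the scatter). Compound 3 remains the closest reference, so no step beyond the scatter is expected in this assay. The main risk is a higher number, given the size of an at least 45-fold higher number from compound 1 to compound 2 (1.65 log units; beyond the scatter).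

The expected change is a 1.2-fold lower number from compound 3 to compound 4 (0.06 log units; within the scatter). For compound 4 the estimate is 200 nM, with an expected range of 40 nM to 2000 nM.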

Compound 4, concentration for 50% growth inhibition: > 10000 nM
Compound 4: only a limit was reported (the forecaster's own chance of this, stated with the estimate: 8%); at least 50-fold (1.69 log units) between middle value and limit.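

In this assay, the aryl group on the carbon with a double bond to nitrogen proves far less permissive than the match between compound 1 and compound 3 suggested: the change to 3,4,5-trimethoxyphenyl gives an at least 43-fold higher number from compound 3 to compound 4 (1.63 log units; beyond the scatter), and the same group entering in place of 4-fluorophenyl gives an at least 45-fold higher number from compound 1 to compound 4 (1.65 log units; beyond the scatter). Compound 4 gives > 10000 nM, which is a limit of the assay and not a number. The earlier compounds shown here showed a large step only for bromo in place of fluoro on an aromatic carbon, whereas this result shows one for a change that keeps the methoxy group of compound 3 and adds further methoxy groups, so among the four compounds only the 4-fluorophenyl and 4-methoxyphenyl groups hold the lower numbers, with compound 2 and compound 4 going against any simple tolerance of this position.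

From the compounds shown here alone, the step from compound 2 to compound 4 cannot be read, so their order remains open: the limit of > 10000 nM in this assay, at which 2 of the 4 values shown sit. Also open is whether a phenyl group bearing an amine or a carboxylic acid would stay level with compound 3 or also reach the limit.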